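The source may report more compounds than this note shows. Statements on the series, on what has been measured and on what is new or still open speak of the compounds shown alone.

Compound 2 `FC(F)SCCc1ccccc1` stands in a physicochemical assay for lipophilicity, read by spectrophotometry, using the shake flask method, measured as octanol-water partition (on this read-out higher numbers stand for higher lipophilicity and lower numbers for lower lipophilicity), at 3.16, level with compound 1 `FC(F)OCCc1ccccc1`, which gives 3.16; the step of no change at the digits printed from compound 1 to compound 2 (within the scatter) is the only one measured so far. Compound 3 `COCCc1ccccc1` carries methoxy in place of (difluoromethyl)sulfanyl on a saturated chain carbon, two bonds along the chain from an aromatic carbon. For the measured compounds named here, the sulfur-for-oxygen part of that change is covered by no change at the digits printed from compound 1 to compound 2 (within the scatter), which was flat, but no measured step covers the loss of the fluorines. Resting on that uncovered part, compound 3 is expected to show the step of a number 0.76 log units lower from compound 2 to compound 3 (beyond the scatter), a drop in this assay. Compound 3 is estimated at 2.4, with a range from 2 to 2.8.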

Compound 3, partition coefficient: 2.23
Compound 3: the middle estimate sits 0.17 log units above what was measured; the range from low to high includes it.
By their numbers in this assay, from the lowest: compound 3; then compounds 1 and 2 (each within the scatter of the next).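

In this assay, methoxy in place of (difluoromethyl)sulfanyl gives a number 0.93 log units lower from compound 2 to compound 3 (beyond the scatter) and methyl in place of difluoromethyl on an oxygen on a saturated carbon gives a number 0.93 log units lower from compound 1 to compound 3 (beyond the scatter). Changes on this saturated chain carbon can therefore move the read-out beyond the scatter, which the flat step between the first two compounds did not show. No measurement on hand gives a reason for these steps.

Open, on these data alone, is whether methylsulfanyl at this place would stand level with methoxy, as the two difluoromethyl compounds stand level. Also open, as far as these compounds go, is where trifluoromethoxy would fall.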